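The compounds below may be only part of what the source reports. "The series", "measured", "known", "first", "only" and "open" are said of these compounds alone.

Measured so far, in an assay on membranes from brain for binding affinity to adenosine receptor A1 (Rattus norvegicus), read by radioligand binding, tested at 20 uM; a lower number here means less inhibition, a higher number more inhibition at the concentration tested (going by the name of the read-out):
Compound 1 `Cn1c(=O)[nH]c2c(cnn2-c2cc(Cl)ccc2Cl)c1=N` gives 1%
Compound 2 `CCCn1ncc2c(=N)n(C)c(=O)[nH]c21` gives 5%
Compound 3 `Cn1c(=O)[nH]c2c(cnn2-c2cccc(Cl)c2)c1=N` gives 53%

Compound 1 stands lowest of the three numbers. Its nearest neighbour is compound 2, a few points higher, and this gap lies within the scatter, so the two cannot be told apart. The furthest is compound 3, whose step a number 52 percentage points higher from compound 1 to compound 3 (beyond the scatter) lies well beyond the scatter.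

Compound 4 `Cn1c(=O)[nH]c2c(cnn2-c2ccccc2Cl)c1=N` is not yet measured. It differs from compound 1 in one place: hydrogen in place of chloro on an aromatic carbon. Among the compounds with values here, the only measured step that bears on this is the one from compound 1 to compound 3, which is also a hydrogen in place of chloro on an aromatic carbon of the same ring, although at a different position; that step was large, a number 52 percentage points higher from compound 1 to compound 3 (beyond the scatter), upward. Because that single step a number 52 percentage points higher from compound 1 to compound 3 (beyond the scatter) was so large, a rise is expected for compound 4 too, but a smaller one, since it is not known whether this second chloro matters as much. The expected step is a number 24 percentage points higher from compound 1 to compound 4 (beyond the scatter), and compound 4 is estimated at 25%, in a range from 2% to 60%.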

Compound 4, a percentage reported as inhibition, at one concentration (the size of the read-out at that concentration, not a potency): 7%
Beside the measured number, compound 4's estimate is 18 percentage points above it, within the range that was stated.
By their numbers in this assay, from the lowest: compounds 1, 2 and 4 (each within the scatter of the next); then compound 3.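

In this assay, swapping this chloro, the one meta to a large group and para to a chloro group, for hydrogen gives a number 6 percentage points higher from compound 1 to compound 4 (within the scatter), so this chloro can go without a readable change in the number. The same kind of swap at the other chloro of compound 1 gave a number 52 percentage points higher from compound 1 to compound 3 (beyond the scatter), which shows that the outcome of removing a chloro from this ring depends on which of the two is removed. Nothing measured here explains why the two chloro groups differ in this way.

As far as these compounds go, it remains open whether a larger or different group on this carbon, such as a methoxy group or an amine, would also leave the number within the scatter. Also open, from the compounds shown here alone, is how a ring with hydrogen in place of both chloro groups would read.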